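Chloro for bromo: a small change on compound 1

A few compounds are considered here, and "the series" means these few. Any claim that something is new, unique, unknown or untested is made for them only; others in the source may bear on it.

Among the compounds with values here, compound 1 `O=C1Nc2ccc(S(=O)(=O)N3CCOCC3)cc2/C1=N/c1ccc(Br)cc1` stands with the lowest of the two numbers measured so far: in a functional assay on HCT-116 cells (Homo sapiens) for cytotoxicity, read by sulforhodamine B assay, with a stated time of 24 h (on this read-out higher numbers stand for weaker inhibition and lower numbers for stronger inhibition), compound 1 gives 15300 nM. Compound 2 `CC(=O)N/N=C1\C(=O)Nc2ccc(S(=O)(=O)N3CCOCC3)cc21`, which carries acetamido in place of 4-bromophenyl on a double-bonded nitrogen, gives in this assay a value of 29000 nM. The step of a 1.9-fold higher number from compound 1 to compound 2 (0.28 log units; within the scatter) is within the scatter, so the two compounds are not separated by this assay.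

Compound 3 `O=C1Nc2ccc(S(=O)(=O)N3CCOCC3)cc2/C1=N/c1ccc(Cl)cc1` differs from compound 1 by chloro in place of bromo on an aromatic carbon. Within the data shown here, the only measured step concerns the group on the double-bonded nitrogen and does not bear on an exchange of one halogen for another; no measured step addresses that change. Accordingly no step beyond the scatter is expected in this assay in either direction, and the expected step of a 1.0-fold lower number from compound 1 to compound 3 (0.01 log units; within the scatter) is small. For compound 3 the estimate in this assay is 15000 nM, with a range from 7000 nM to 35000 nM.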

Compound 3, half-maximal inhibitory concentration: 24300 nM
Compound 3: the middle estimate sits 1.6-fold (0.21 log units) below what was measured; the range from low to high includes it.
By their numbers in this assay, from the lowest: compounds 1, 3 and 2 (each within the scatter of the next).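

On the aromatic carbon para to a large group, chloro in place of bromo gives a 1.6-fold higher number from compound 1 to compound 3 (0.20 log units; within the scatter) in this assay, so this exchange of one halogen for another is not resolved by the read-out. The group on the double-bonded nitrogen is now read with a second aryl partner, 4-chlorophenyl in place of acetamido giving a 1.2-fold lower number from compound 2 to compound 3 (0.08 log units; within the scatter), so this exchange leaves its two compounds unseparated, as 4-bromophenyl and acetamido were. Nothing available bears on why these steps are so small.

With only two halogens at this position, the compounds shown leave open whether it responds to any change at all. A methoxy group, an amine or a carboxylic acid on that aromatic carbon would put the question to groups of a different kind.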